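Octyl to 4,4,4-trifluorobutyl on the shared core

The compounds below may be only part of what the source reports. "The series", "measured", "known", "first", "only" and "open" are said of these compounds alone.

compound 1 `CCCCCCCCNc1ccc(C(=O)O)cc1S(N)(=O)=O`: > 250000 nM (a limit of the assay)
compound 2 `CCCCCCCCNc1ccc(C(=O)O)cc1S(=O)(=O)N(C)C`: 52000 nM

These two compounds were measured in a physicochemical assay for solubility, in phosphate buffer, measured as kinetic solubility, at pH 7.4, tested at 250 uM; on this read-out lower numbers stand for lower solubility and higher numbers for higher solubility. Of the two readings, only compound 2 gives an actual number, 52000 nM. Compound 1 reports > 250000 nM, which is a limit of the assay. For the measured compounds named here, the one measured step, an at least 4.8-fold lower number from compound 1 to compound 2 (0.68 log units; beyond the scatter), comes with dimethylamino in place of amino on a sulfonyl sulfur.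

Compound 3 `CN(C)S(=O)(=O)c1cc(C(=O)O)ccc1NCCCC(F)(F)F` keeps the dimethylamino group and alters the chain instead: trifluoromethyl in place of pentyl on a saturated chain carbon, three bonds along the chain from a nitrogen on an aromatic ring. The same difference reads octyl to 4,4,4-trifluorobutyl. Going by the values given here, no measured step touches the chain, so the step at the sulfur bears on it only indirectly, showing that one change can move this assay beyond the scatter. Compound 2, at 52000 nM, leaves room for a rise. Any such rise can be reported as a number only up to the limit of > 250000 nM in this assay, at which 1 of the 2 values shown sits. The expected change is modest and upward, an estimated 2.5-fold higher number from compound 2 to compound 3 (0.40 log units; beyond the scatter). For compound 3 the expected value is 130000 nM, with an estimated range of 45000 nM to 250000 nM.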

Compound 3, solubility: 245000 nM
The estimate for compound 3 lay 1.9-fold (0.28 log units) below the measured number; low and high end bracket the measured number.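

The chain now has a measured step of its own: in this assay, trifluoromethyl in place of pentyl on a saturated chain carbon, three bonds along the chain from a nitrogen on an aromatic ring, gives a 4.7-fold higher number from compound 2 to compound 3 (0.67 log units; beyond the scatter). So this position, and not only the sulfonyl sulfur, can move the read-out beyond the scatter, and the change here runs toward a higher number, whereas the step at the sulfur ran toward a lower one. Compound 3 stands at 245000 nM, so a further rise from this chain would leave little room to be read as a number in this assay: the limit of > 250000 nM in this assay, at which 1 of the 3 values shown sits.

The single step swaps octyl for 4,4,4-trifluorobutyl, so it shortens the chain and brings in fluorine at once, and the compounds shown do not tell these two apart, as a plain butyl chain is not among them. Also open, as far as these compounds go, is whether the same chain change would act alike with amino on the sulfonyl sulfur, or whether a group such as a terminal hydroxyl or an ether within the chain would move the number in the same direction.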